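The source may report more compounds than this note shows. Statements on the series, on what has been measured and on what is new or still open speak of the compounds shown alone.

Measured so far in a functional assay on BMDM cells (Mus musculus, strain C57BL/6) for inhibition, with a stated time of 2 days; a lower number here means a stronger inhibitor, a higher number a weaker inhibitor:
compound 1, `O=C(Cn1cc(-c2ccccc2Cl)nn1)Nc1nccs1`, 60 nM;
compound 2, `O=C(Cn1cc(-c2cccc(Cl)c2)nn1)Nc1nccs1`, > 30000 nM.

Compound 2 sits at the limit of this assay, so only a bound is known for it. The step of an at least 500-fold higher number from compound 1 to compound 2 (2.69 log units; beyond the scatter) is large, its size resting on (the limit of > 30000 nM in this assay, at which 1 of the 2 values shown sits). Compound 3, `O=C(Cn1cc(-c2cccs2)nn1)Nc1nccs1`, differs from compound 2 by thiophen-2-yl in place of 3-chlorophenyl on an aromatic carbon. Going by the values given here, no measured step concerns a thiophen-2-yl group, and the single measured step exchanges 2-chlorophenyl for 3-chlorophenyl only, so it offers no direct guide; the expectation for compound 3 is a return to a measurable number, an estimated at least 3.7-fold lower number from compound 2 to compound 3 (0.57 log units; beyond the scatter). The estimate for compound 3 in this assay is 8000 nM, within 500 nM to 30000 nM.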

Compound 3, half-maximal inhibitory concentration: > 30000 nM
Compound 3 gave a limit, no number; the forecaster's own chance of this, stated with the estimate: 45%; middle value at least 3.7-fold (0.57 log units) away from the limit.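

The change to thiophen-2-yl gives an at least 500-fold higher number from compound 1 to compound 3 (2.69 log units; beyond the scatter), so a five-membered aromatic ring on this carbon, like 3-chlorophenyl, leaves no measurable number in this assay. Compound 2 and compound 3 both stand at a limit, and the step between them cannot be read. Of the three groups shown, only 2-chlorophenyl gives a number, and the size of this step rests on a limit: the limit of > 30000 nM in this assay, at which 2 of the 3 values shown sit.

Open, from the compounds shown here alone, is whether plain phenyl, 2-fluorophenyl or 2-methylphenyl on this carbon would give a number. Also open, going by these compounds, is whether a substituted thiophene would restore one.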